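The source may hold more compounds than are shown below. What is called first, only, known or untested is meant among the compounds shown, and "the series" means these compounds.

Measured compounds:
- compound 1 `c1cnc2c(c1)CCC[C@@H]2N(CCCN1CCNCC1)Cc1cc2ccccc2cn1`: 17 nM
- compound 2 `CCN1CCN(CCCN(C[C@H]2Cc3ccccc3CN2)[C@H]2CCCc3cccnc32)CC1`: 33 nM
- compound 3 `NC(=O)N1CCN(CCCN(C[C@H]2Cc3ccccc3CN2)[C@H]2CCCc3cccnc32)CC1`: 959 nM

In a functional assay on CCRF-CEM cells for antagonist activity at C-X-C chemokine receptor type 4 (Homo sapiens), read by calcium flux, with stated times of 25 min and 90 s (on this read-out lower numbers stand for stronger inhibition and higher numbers for weaker inhibition), compound 1 gives 17 nM, the lowest number of the three, though compound 2 with 33 nM sits within the usual scatter of it, so the two cannot be ranked. Within the data shown here, compound 3, at 959 nM, stands well apart; the single one-place step known here, a 29-fold higher number from compound 2 to compound 3 (1.46 log units; beyond the scatter), concerns carbamoyl in place of ethyl on the amine nitrogen in the ring and does not touch the part of the molecule changed now.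

Compound 4 `c1cnc2c(c1)CCC[C@@H]2N(CCCN1CCNCC1)Cc1nc2ccccc2s1` differs from compound 1 by 1,3-benzothiazol-2-yl in place of isoquinolin-3-yl on a saturated chain carbon bound to an amine nitrogen. Among the measured compounds shown here, no measured pair shows what swapping one aromatic bicycle for another at this position does, so there is no step to lean on; both groups are flat aromatic systems of similar size, and the rest of the molecule is unchanged. A small shift, within or only slightly beyond the scatter, is the most reasonable expectation, with a somewhat weaker outcome a little likelier than a stronger one. Compound 4 is therefore estimated at 40 nM, between 10 nM and 200 nM, which would mean a step of a 2.4-fold higher number from compound 1 to compound 4 (0.37 log units; beyond the scatter).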

Compound 4, half-maximal inhibitory concentration: 1200 nM
Compound 4: the middle estimate sits 30-fold (1.48 log units) below what was measured; the measured number lies above the stated range.
By their numbers in this assay, from the lowest: compounds 1 and 2 (each within the scatter of the next); then compounds 3 and 4 (each within the scatter of the next).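

In this assay, 1,3-benzothiazol-2-yl in place of isoquinolin-3-yl gives a 71-fold higher number from compound 1 to compound 4 (1.85 log units; beyond the scatter), so one two-ring aromatic group cannot simply stand in for another at this place, on a saturated chain carbon bound to an amine nitrogen. The earlier step concerned only the amine nitrogen in a ring, whereas this one shows that the number also depends strongly on which group sits at this second place. The entering group has a five-membered aromatic ring with 2 hetero atoms where the leaving group has a six-membered one with 1, but no measurement on hand explains the rise.

On these data alone, it remains open whether the sulfur or the five-membered ring goes with the higher number. A 1,3-benzoxazol-2-yl or quinolin-2-yl group at this place could help separate the two.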